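Compound 1 to compound 3: ethenyl to ethyl

This account rests on a few compounds, and the source may have more. Where it says the series, first, only, none or still open, it means among the compounds named here.

Measured so far in a functional assay on HepG2 cells (Homo sapiens) for inhibition, read by MTT assay, with a stated time of 120 h; a lower number here means a stronger inhibitor, a higher number a weaker inhibitor:
compound 1 `CNC(=O)/C=C/c1ccc(NC(=O)Nc2ccc(Cl)c(C(F)(F)F)c2)cc1` gives 20400 nM
compound 2 `CC1CN(C(=O)/C=C/c2ccc(NC(=O)Nc3ccc(Cl)c(C(F)(F)F)c3)cc2)CC(C)O1` gives 45900 nM

Within the data shown here, compound 1 holds the lower of the two numbers, and compound 2 is its only neighbour, with a 2.3-fold higher number from compound 1 to compound 2 (0.35 log units; beyond the scatter) as the measured gap. Compound 3 `CNC(=O)CCc1ccc(NC(=O)Nc2ccc(Cl)c(C(F)(F)F)c2)cc1` carries 2-(methylcarbamoyl)ethyl in place of 2-(methylcarbamoyl)ethenyl on an aromatic carbon para to a large group. Among the measured compounds shown here, the one measured step, a modest one, changes the group on the carbonyl carbon, so it bears only indirectly. For the measured compounds named here, no measured step touches this chain. A similarly small step in this assay is therefore expected, slightly upward if anything: a 1.2-fold higher number from compound 1 to compound 3 (0.09 log units; within the scatter) is the estimated step. For compound 3 the estimated value is 25000 nM within an expected range of 10000 nM to 60000 nM in this series.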

Compound 3, half-maximal inhibitory concentration: 21000 nM
For compound 3 the middle estimate is 1.2-fold (0.08 log units) above the measured one; low and high end bracket the measured number.
By their numbers in this assay, from the lowest: compounds 1 and 3 (each within the scatter of the next); then compound 2.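

In this assay, among these compounds, the step of a 1.0-fold higher number from compound 1 to compound 3 (0.01 log units; within the scatter) is the first reading on the chain itself, on an aromatic carbon para to a large group, since the earlier step changed only the group on the carbonyl carbon. With 2-(methylcarbamoyl)ethyl in place of 2-(methylcarbamoyl)ethenyl, the number stays within the scatter, so the double bond of this chain is not required for the activity seen here. No measurement on hand explains this result.

Still open, on these data alone, is whether a longer chain or a carboxylic acid at this position would shift the number. Also open, as far as these compounds go, is whether the 2,6-dimethylmorpholin-4-yl step, a 2.3-fold higher number from compound 1 to compound 2 (0.35 log units; beyond the scatter) on the ethenyl chain, carries over to the ethyl chain.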